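Lengthening the Amine Again: From Dimethyl to Butyl

This account rests on a few compounds, and the source may have more. Where it says the series, first, only, none or still open, it means among the compounds named here.

Compound 1 `CCCN(CCC)Cc1ccc(Cl)c(-c2ccccc2OC)c1` in an assay on isolated protein for binding affinity to 5-hydroxytryptamine receptor 6 (Homo sapiens) (on this read-out lower numbers stand for stronger inhibition and higher numbers for weaker inhibition), returns only a limit, > 10000 nM.
Compound 2 `COc1ccccc1-c1cc(CN(C)C)ccc1Cl` in this assay gives 440 nM.

Compound 2 therefore holds the only number shown; the other value is a limit. Compound 3 `CCCCNCc1ccc(Cl)c(-c2ccccc2OC)c1` differs from compound 2 by butylamino in place of dimethylamino on a saturated chain carbon bound to an aromatic carbon. Among the compounds with values here, the one measured step that bears on this change is an at least 22-fold lower number from compound 1 to compound 2 (1.35 log units; beyond the scatter), in which the amine shrank from dipropylamino to dimethylamino and the number fell sharply; since compound 1 sits at the limit of > 10000 nM in this assay, at which 1 of the 2 values shown sits, the full size of that fall is unknown. Compound 3 lengthens the amine again, though less far than dipropylamino does, and the number in this assay is expected to rise, with a 4.5-fold higher number from compound 2 to compound 3 (0.66 log units; beyond the scatter). Compound 3 is estimated at 2000 nM, within a range from 500 nM to 10000 nM.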

Compound 3, inhibition constant: 240 nM
Beside the measured number, compound 3's estimate is 8.3-fold (0.92 log units) above it, and the stated range ends above it.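

On this saturated chain carbon bound to an aromatic carbon, butylamino in place of dimethylamino gives a 1.8-fold lower number from compound 2 to compound 3 (0.26 log units; within the scatter), so this assay does not separate these two amines. Butylamino in place of dipropylamino gives an at least 41-fold lower number from compound 1 to compound 3 (1.61 log units; beyond the scatter), which shows that a longer amine chain alone does not bring the loss seen with dipropylamino. The value of compound 1, > 10000 nM, is a limit, so this step has no full size: the limit of > 10000 nM in this assay, at which 1 of the 3 values shown sits.

Butylamino differs from dimethylamino in both its chain and its hydrogen-bond donor, and the compounds shown do not separate these two differences, as a butyl(methyl)amino group could. On these data alone, it also remains open how a shorter ethylamino group or a piperidine ring at this place would read in this assay.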